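The source may hold more compounds than are shown below. What is called first, only, known or untested is meant among the compounds shown, and "the series" means these compounds.

Three compounds of this series have been run in a functional assay on A-431 cells (Homo sapiens) for cytotoxicity, read by MTT assay, with a stated time of 72 h, tested at 1 uM; a lower number here means less inhibition of growth, a higher number more inhibition of growth at the concentration tested. Compound 1 `N/C(=N\NC(=S)N1CCCCCC1)c1ccccn1` gives 18.8%. Compound 2 `N/C(=N\NC(=S)N1CCOCC1)c1ccccn1` gives 29.2%; how the core of compound 1 differs from the core of compound 2 is not broken down here. Compound 3 `N/C(=N\NC(=S)N1CCOCC1)c1ccc(F)cn1` gives 31.8%. From compound 2 to compound 3 the change is fluoro in place of hydrogen on an aromatic carbon and the step is a number 2.6 percentage points higher from compound 2 to compound 3 (within the scatter). Compound 4 `N/C(=N\NC(=S)N1CCCCCC1)c1ccc(F)cn1` has not yet been measured; it differs from compound 1 by fluoro in place of hydrogen on an aromatic carbon, the same change as from compound 2 to compound 3. The step from compound 1 to compound 4 in this assay is expected to be a number 2.2 percentage points higher from compound 1 to compound 4 (within the scatter), resting on the earlier pair because a number 2.6 percentage points higher from compound 2 to compound 3 (within the scatter) stayed within the scatter. Compound 4 is therefore estimated at 21%, expected to fall between 9% and 34%.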

Compound 4, percent growth inhibition at one concentration: 50.3%
Compound 4: middle estimate off by 29.3 percentage points, on the low side, and the stated range ends below it.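

In this assay, fluoro in place of hydrogen on an aromatic carbon comes out as a number 31.5 percentage points higher from compound 1 to compound 4 (beyond the scatter). The size of this change therefore does not carry over from one core to the other in this series: the same change on two cores in this assay, a number 2.6 percentage points higher (within the scatter) from compound 2 to compound 3 and a number 31.5 percentage points higher (beyond the scatter) from compound 1 to compound 4, 28.9 percentage points apart, beyond the scatter of two such steps
This shows that the step depends on the core for these two pairs, but it does not show why, and two pairs give no rule for predicting the step on a third core.

Still open, on these data alone, is whether another group at the same place, such as chloro or methoxy, would also give steps that differ between the two cores. Also open is whether the gap between the two steps persists at other concentrations, with a single concentration shown here.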